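The source may report more compounds than this note shows. Statements on the series, on what has been measured and on what is new or still open speak of the compounds shown alone.

Measured so far in a functional assay on MCF7 cells (Homo sapiens) for inhibition, read by sulforhodamine B assay; a higher number here means a weaker inhibitor of growth, a lower number a stronger inhibitor of growth:
- compound 1 `Cc1ccc2[nH]c(-c3ccc(-c4ccc(-c5ccc(N(C)C)cc5)cc4)cc3)nc2c1` gives 3130 nM
- compound 2 `Fc1ccc(-c2ccc(-c3ccc(-c4nc5ccccc5[nH]4)cc3)cc2)cc1` gives 36200 nM
- compound 3 `Oc1cccc2[nH]c(-c3ccc(-c4ccc(-c5ccc(F)cc5)cc4)cc3)nc12` gives 3010 nM

Compound 3 at 3010 nM lies within the scatter of compound 1 at 3130 nM and well under compound 2 at 36200 nM on this scale. Among the measured compounds shown here, the only measured step, hydroxy in place of hydrogen, is a 12-fold lower number from compound 2 to compound 3 (1.08 log units; beyond the scatter) and it lies elsewhere in the molecule. Compound 4 `COc1ccc(-c2ccc(-c3ccc(-c4nc5c(O)cccc5[nH]4)cc3)cc2)cc1OC` keeps that hydroxy, and its change from compound 3 is 3,4-dimethoxyphenyl in place of 4-fluorophenyl on an aromatic carbon and nothing else. For the measured compounds named here, no measured step covers this swap, though compound 1, with another group there and a further core difference, stays at 3130 nM in the same range. No step beyond the scatter is therefore expected in this assay in either direction. The expected step is a 1.2-fold higher number from compound 3 to compound 4 (0.07 log units; within the scatter) by this estimate. Compound 4 is estimated at 3500 nM with an expected range from 1200 nM to 10000 nM as the likely span.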

Compound 4, concentration for 50% growth inhibition: 190 nM
Beside the measured number, compound 4's estimate is 18-fold (1.27 log units) above it; measured number below the stated range.
By their numbers in this assay, from the lowest: compound 4; then compounds 3 and 1 (each within the scatter of the next); then compound 2.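

In this assay the group on this aromatic carbon proves to matter: 3,4-dimethoxyphenyl in place of 4-fluorophenyl gives a 16-fold lower number from compound 3 to compound 4 (1.20 log units; beyond the scatter) with the hydroxy kept. Together with a 12-fold lower number from compound 2 to compound 3 (1.08 log units; beyond the scatter) in the hydroxy step, this shows single changes at two separate places each moving the number beyond the scatter. Nothing available accounts for the size of this step.

The compounds shown leave open whether a single methoxy would give the same step, and whether it depends on the hydroxy. On these data alone, how an amine or a longer ethoxy chain would read here also stays open.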